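The source may hold more compounds than are shown below. What is called first, only, known or untested is meant among the compounds shown, and "the series" means these compounds.

Values measured in a functional assay on MOLT-4 cells (Homo sapiens) for inhibition; on this read-out higher numbers stand for weaker inhibition and lower numbers for stronger inhibition:

- Compound 1 `O=C1/C(=C/c2ccc(F)cc2)Cc2ccccc21`: 60000 nM
- Compound 2 `Cc1cccc(/C=C2\Cc3ccccc3C2=O)c1`: 80300 nM
- Compound 3 `O=C1/C(=C/c2ccc(F)cc2)CCCc2ccccc21`: 53600 nM

Compound 3, at 53600 nM, lies within the scatter of both other compounds, so the three cannot be ranked. Compound 4 `COc1ccc(/C=C2\CCCc3ccccc3C2=O)cc1` has not yet been measured. It carries methoxy in place of fluoro on an aromatic carbon, para to a large group: methoxy in place of fluoro on an aromatic carbon. Within the data shown here, no measured pair shows what a single change does in this assay. Since compound 1 at 60000 nM and compound 2 at 80300 nM also lie close together, no step beyond the scatter is expected. The expected change is a 1.3-fold lower number from compound 3 to compound 4 (0.11 log units; within the scatter). For compound 4 the estimate is 42000 nM, with an expected range of 16000 nM to 95000 nM.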

Compound 4, half-maximal inhibitory concentration: 470 nM
For compound 4 the middle estimate is 89-fold (1.95 log units) above the measured one; the measured number lies below the stated range.
By their numbers in this assay, from the lowest: compound 4; then compounds 3, 1 and 2 (each within the scatter of the next).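

In this assay methoxy in place of fluoro on an aromatic carbon, para to a large group, gives a 110-fold lower number from compound 3 to compound 4 (2.06 log units; beyond the scatter) and is the only single change shown here. Among these compounds, it shows that the read-out responds strongly to what this position carries, which the earlier compounds, all within the scatter of one another, could not show. Nothing available explains the size of this step. Going by these compounds, it remains open whether a hydroxy group, an ethoxy group or an amine at this position would give a similar number, and whether methoxy would have a similar effect on the core of compound 1.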